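The source may hold more compounds than are shown below. What is called first, only, known or untested is meant among the compounds shown, and "the series" means these compounds.

Measured so far in an assay for inhibition of Amine oxidase [flavin-containing] A (Rattus norvegicus); a lower number here means a stronger inhibitor, a higher number a weaker inhibitor:
compound 1, `Cc1ccc(COc2ccc(-c3nn(CCC#N)c(=O)o3)cc2)cc1`, gives 25000 nM.
compound 2, `N#CCCn1nc(-c2ccc(OCc3cccc(Cl)c3)cc2)oc1=O`, gives 7400 nM.
compound 3, `Cc1ccc(COc2ccc(-c3nn(CCC#N)c(=S)o3)cc2)cc1`, gives 10000 nM.

Compound 1 and compound 2 differ in a single place: 3-chlorophenyl in place of 4-methylphenyl on a saturated chain carbon bound to an oxygen on an aromatic ring. The step it made was a 3.4-fold lower number from compound 1 to compound 2 (0.53 log units; beyond the scatter). Compound 3 carries the same 4-methylphenyl as compound 1, but the two differ in more than one place, and the difference between the two cores is not broken down here. In this assay compound 3 gives 10000 nM, which is within the usual scatter of compound 2 at 7400 nM. Against compound 1 at 25000 nM, the gap for compound 3 lies beyond the scatter.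

Compound 4, `N#CCCn1nc(-c2ccc(OCc3cccc(Cl)c3)cc2)oc1=S`, has not been measured in this assay. It stands to compound 3 exactly as compound 2 stands to compound 1: 3-chlorophenyl in place of 4-methylphenyl on a saturated chain carbon bound to an oxygen on an aromatic ring. The place is described in the same words for both pairs, so this is the same change, seen twice among these compounds. Among the compounds with values here, only one measured instance exists, and it was made on the core of compound 1, not on the core of compound 3, so the transfer is uncertain. Still, a step of about a 3.3-fold lower number from compound 3 to compound 4 (0.52 log units; beyond the scatter) is expected for compound 4, because the step of a 3.4-fold lower number from compound 1 to compound 2 (0.53 log units; beyond the scatter) went beyond the scatter in a single place. On that basis compound 4 is estimated at 3000 nM in this assay, with a likely range from 1200 nM to 8000 nM.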

Compound 4, half-maximal inhibitory concentration: 11000 nM
Estimate against measurement, compound 4: 3.7-fold (0.56 log units) below; the measured number lies above the stated range.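

On the core of compound 3, 3-chlorophenyl in place of 4-methylphenyl gave a 1.1-fold higher number from compound 3 to compound 4 (0.04 log units; within the scatter) in this assay, so the lower number seen on the core of compound 1 did not carry over to this second core. Within the data shown here, the change therefore cannot be treated as a fixed increment, since the size of its step depended on the core that carried it: the same change on two cores in this assay, a 3.4-fold lower number (0.53 log units; beyond the scatter) from compound 1 to compound 2 and a 1.1-fold higher number (0.04 log units; within the scatter) from compound 3 to compound 4, 3.7-fold (0.57 log units) apart, beyond the scatter of two such steps These two pairs show only that the step failed to transfer between these two cores; they do not show why it failed, and they cannot tell how the same change would behave on any other core.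

From the compounds shown here alone, all four compounds carry the same chain ending in a nitrile, so it remains open how the numbers in this assay would respond to a longer chain or to a carboxylic acid or an amine at the end of it. Going by these compounds, it also remains open whether a group other than 3-chlorophenyl or 4-methylphenyl, such as a 4-methoxyphenyl or an unsubstituted phenyl, would give steps that agree on the two cores.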